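Swapping a Trifluoromethyl for a Fluorinated Formylphenyl

A few compounds are considered here, and "the series" means these few. Any claim that something is new, unique, unknown or untested is made for them only; others in the source may bear on it.

Within the data shown here, compound 1 `Cc1c(Cc2ccc(C(F)(F)F)cc2)c(=O)oc2cc(OCC(O)CN3CCC(C(N)=O)CC3)ccc12` is measured in an ADME assay on A549 cells (Homo sapiens) for cytotoxicity, read by CellTiter-Glo (a lower number here means that less compound is tolerated, a higher number that more compound is tolerated), where compound 1 gives 89300 nM, the only number recorded here. Compound 2 `Cc1c(Cc2ccccc2C(F)(F)F)c(=O)oc2cc(OCC(O)CN3CCC(C(N)=O)CC3)ccc12` reached only a limit of the assay, > 100000 nM. That corresponds to an at least 1.1-fold higher number from compound 1 to compound 2 (0.04 log units; that floor lies within the scatter), a step within the scatter. Compound 3 `Cc1c(Cc2ccc(-c3ccc(C=O)c(F)c3)cc2)c(=O)oc2cc(OCC(O)CN3CCC(C(N)=O)CC3)ccc12` differs from compound 1 by 3-fluoro-4-formylphenyl in place of trifluoromethyl on an aromatic carbon. Among the measured compounds shown here, no measured step covers such a replacement, so the expectation rests only on the steadiness seen so far. Compound 3 is expected to give 65000 nM, between 20000 nM and 100000 nM. That estimate means a 1.4-fold lower number from compound 1 to compound 3 (0.14 log units; within the scatter), no step beyond the scatter.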

Compound 3, half-maximal cytotoxic concentration: 62400 nM
Estimate against measurement, compound 3: 1.0-fold (0.02 log units) above; low and high end bracket the measured number.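

Putting a whole extra aromatic ring carrying a formyl group on this aromatic carbon, in place of trifluoromethyl, gives a 1.4-fold lower number from compound 1 to compound 3 (0.16 log units; within the scatter) in this assay. The incoming group has 9 heavy atoms against 4 for the one that leaves, yet the step stays within the scatter, so in this pair the position accepts a far bigger group without a clear shift.

Compound 2 gives a limit and not a number: the limit of > 100000 nM in this assay, at which 1 of the 3 values shown sits.

On these data alone, whether an amine or a carboxylic acid on this aromatic carbon would leave the number in the same range stays open.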